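A few compounds are considered here, and "the series" means these few. Any claim that something is new, unique, unknown or untested is made for them only; others in the source may bear on it.

Within the data shown here, compound 1, `Nc1cc(N)c2nc(-c3ccccc3)c(Oc3ccc(F)cc3)nc2c1`, is one of three compounds measured in a functional assay on SF-539 cells (Homo sapiens) for inhibition, read by sulforhodamine B assay, with a stated time of 48 h; a lower number here means that less compound is tolerated, a higher number that more compound is tolerated. In this assay compound 1 gives 70800 nM. Compound 2, `COc1cc(CNc2nc3cc(N)cc(N)c3nc2-c2ccccc2)cc(OC)c1OC`, gives 26900 nM in this assay, so of the two plain numbers compound 1 is the higher one, with compound 2 lying beneath it by a gap that goes beyond the usual scatter. Compound 3, `COc1ccc(CNc2nc3cc(N)cc(N)c3nc2-c2ccccc2)cc1OC`, comes back at the limit of < 100000 nM in this assay, at which 1 of the 3 values shown sits, which means that in this assay compound 3 gives < 100000 nM, a limit of the assay and not a number. Hence a step that the limit leaves unreadable from compound 2 to compound 3.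

Compound 4, `COc1ccc(Sc2nc3cc(N)cc(N)c3nc2-c2ccccc2)cc1`, differs from compound 1 in one place: (4-methoxyphenyl)sulfanyl in place of 4-fluorophenoxy on an aromatic carbon. Neither measured step touches this position. Among the measured compounds shown here, the only measured step, from compound 2 to compound 3, swaps a methoxy for hydrogen elsewhere on the core and is itself unreadable, so it offers no guide to the size or direction of the present change. For compound 4 the estimate is therefore 70000 nM, with a range from 30000 nM to 150000 nM. The step this means, a 1.0-fold lower number from compound 1 to compound 4 (0.00 log units; within the scatter), is expected to stay within the scatter. Since compound 1 already sits near the top of the numbers seen, a reading for compound 4 that ends as a limit rather than a number remains quite possible.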

Compound 4, concentration lethal to 50% of the cells: < 100000 nM
Compound 4 ended at the assay's limit (the forecaster's own chance of this, stated with the estimate: 35%); the middle value does not contradict the limit.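

In this assay, compound 4 gives < 100000 nM, a limit of the assay and not a number. Among these compounds, no new step can therefore be read between compound 1 and compound 4. The compounds shown leave open whether (4-methoxyphenyl)sulfanyl in place of 4-fluorophenoxy changes the number at all, and if so, in which direction and by how much.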